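The source may report more compounds than this note shows. Statements on the series, on what has been measured and on what is new or still open speak of the compounds shown alone.

Compound 1 `CCCN(CC1CC1)c1nc(-c2ccc(Cl)cc2OC)n(C)n1`: 2600 nM
Compound 2 `CCCN(CCC)c1nc(-c2ccc(Cl)cc2OC)n(C)n1`: > 10000 nM

In an in vitro assay on Ltk- cells for binding affinity to corticotropin-releasing factor receptor 1 (Homo sapiens) (on this read-out higher numbers stand for weaker inhibition and lower numbers for stronger inhibition), compound 1 gives 2600 nM. For compound 2 the read-out is only a limit of the assay, > 10000 nM. Compound 2 thus stands at the limit of > 10000 nM in this assay, at which 1 of the 2 values shown sits, with no number of its own. Among the measured compounds shown here, the single measured step, an at least 3.8-fold higher number from compound 1 to compound 2 (0.58 log units; beyond the scatter), ends at that limit.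

Compound 3 `CCCCC(CC)N(CCC)c1nc(-c2ccc(Cl)cc2OC)n(C)n1` differs from compound 2 by butyl in place of hydrogen on a saturated chain carbon bound to a nitrogen on an aromatic ring and a saturated chain carbon. The measured step concerned a different exchange at the same nitrogen, so it bears only loosely on this change; it shows that the assay already reports no number for compound 2, and a further step upward could not be seen at all. No step beyond the scatter can be foreseen in this assay. Compound 3 is therefore expected to give 12000 nM, in the range 3000 nM to 50000 nM, meaning a step that the limit leaves unreadable from compound 2 to compound 3 and most likely again only a limit.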

Compound 3, inhibition constant: 46 nM
Compound 3: middle estimate off by 260-fold (2.42 log units), on the high side, outside the stated range (below it).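

At this position, butyl in place of hydrogen on a saturated chain carbon bound to a nitrogen on an aromatic ring and a saturated chain carbon turns propyl into 1-ethylpentyl, and in this assay this gives an at least 210-fold lower number from compound 2 to compound 3 (2.33 log units; beyond the scatter). The earlier step showed only a move toward weaker inhibition at this nitrogen, whereas 1-ethylpentyl in place of cyclopropylmethyl on the nitrogen gives a 57-fold lower number from compound 1 to compound 3 (1.75 log units; beyond the scatter). The first of these steps can be read only as a bound, as compound 2 has no number of its own: the limit of > 10000 nM in this assay, at which 1 of the 3 values shown sits.

On these data alone, it remains open whether a shorter chain on that same carbon, such as methyl or ethyl, would already give a step of this kind. Also open, as far as these compounds go, is how the read-out would respond to an ether oxygen or an amine in place of the end of the butyl chain.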